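A few compounds are considered here, and "the series" means these few. Any claim that something is new, unique, unknown or untested is made for them only; others in the source may bear on it.

Compound 1 `CC(C)(Oc1ccc(F)cc1)C1OCC(C/C=C\CCC(=O)O)C(c2cccnc2)O1`: 120 nM
Compound 2 `COc1ccccc1OC(C)(C)C1OCC(C/C=C\CCC(=O)O)C(c2cccnc2)O1`: 224 nM

Among the compounds with values here, in a functional assay for inhibition, with Homo sapiens as the target (a higher number here means weaker binding, a lower number tighter binding), compound 2 gives 224 nM, which lies within the scatter of the only other measured number. Compound 3 `CSc1ccccc1OC(C)(C)C1OCC(C/C=C\CCC(=O)O)C(c2cccnc2)O1` has methylsulfanyl in place of methoxy on an aromatic carbon, ortho to a large group (methylsulfanyl in place of methoxy on an aromatic carbon). Within the data shown here, no measured step makes this exchange. The nearest evidence is a 1.9-fold higher number from compound 1 to compound 2 (0.27 log units; within the scatter), a change of the whole 2-methoxyphenyl group, so no shift beyond the scatter is expected in either direction. The expected result is a 1.1-fold lower number from compound 2 to compound 3 (0.05 log units; within the scatter). For compound 3 the estimated value is 200 nM, with an expected range of 85 nM to 470 nM.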

Compound 3, dissociation constant: 89.1 nM
For compound 3 the middle estimate is 2.2-fold (0.35 log units) above the measured one, within the range that was stated.
By their numbers in this assay, from the lowest: compounds 3, 1 and 2 (each within the scatter of the next, the first and the last beyond it).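

Within the data shown here, at this place on the aromatic ring, ortho to a large group, methylsulfanyl in place of methoxy gives the first change beyond the scatter in this assay (a 2.5-fold lower number from compound 2 to compound 3 (0.40 log units; beyond the scatter)). Compound 3 still lies within the scatter of compound 1, which carries 4-fluorophenyl instead (a 1.3-fold lower number from compound 1 to compound 3 (0.13 log units; within the scatter)). Nothing measured here explains why this exchange moves the number. Still open, as far as these compounds go, is how an amine or a longer chain such as ethylsulfanyl would behave at this same place. From the compounds shown here alone, it is also open whether the exchange would move the number similarly on a different core.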